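Carbonyl substituent change from compound 2 toward compound 4

The source may hold more compounds than are shown below. What is called first, only, known or untested is meant among the compounds shown, and "the series" means these compounds.

Measured compounds:
compound 1 `COc1cc(-c2nn(-c3cccc(NC(=O)Nc4cc(C(F)(F)F)cc(C(F)(F)F)c4)c3)cc2-c2ccncc2)ccc1Cl` — 1700 nM
compound 2 `COc1cc(-c2nn(-c3cccc(NC(=O)c4cccc(C(F)(F)F)c4)c3)cc2-c2ccncc2)ccc1Cl` — > 50000 nM
compound 3 `O=C(Nc1cccc(-n2cc(-c3ccncc3)c(-c3ccc(Cl)c(O)c3)n2)c1)Nc1cc(C(F)(F)F)cc(C(F)(F)F)c1` — 1570 nM

In a functional assay on SK-MEL-28 cells (Homo sapiens) for inhibition, read by sulforhodamine B assay, with a stated time of 48 h (on this read-out higher numbers stand for weaker inhibition of growth and lower numbers for stronger inhibition of growth), compound 2 gives > 50000 nM, which is a limit of the assay and not a number. Going by the values given here, compound 2 is the one measured compound that sits at this limit (the limit of > 50000 nM in this assay, at which 1 of the 3 values shown sits), whereas compound 1 and compound 3 each give a numerical value. Compound 4 `COc1cc(-c2nn(-c3cccc(NC(=O)Nc4ccc(Cl)c(C(F)(F)F)c4)c3)cc2-c2ccncc2)ccc1Cl` differs from compound 2 by (4-chloro-3-(trifluoromethyl)phenyl)amino in place of 3-(trifluoromethyl)phenyl on a carbonyl carbon. Among the compounds with values here, the only measured single-site step, a 1.1-fold lower number from compound 1 to compound 3 (0.03 log units; within the scatter), concerns the oxygen on the aromatic ring and does not touch the carbonyl carbon, so it gives no direct measure of the present change. What does bear on it is that compound 1 and compound 3 both carry an arylamino group on the carbonyl carbon, as compound 4 will, and in this assay compound 1 gives 1700 nM while compound 3 gives 1570 nM. Compound 2, with an aryl group directly on the carbonyl carbon, stands only at the limit. The step in this assay is therefore expected to be large and toward stronger inhibition of growth, estimated as an at least 25-fold lower number from compound 2 to compound 4 (1.39 log units; beyond the scatter). For compound 4 the expected value is 2000 nM, with a range from 600 nM to 8000 nM.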

Compound 4, concentration for total growth inhibition: 5010 nM
Compound 4: the middle estimate sits 2.5-fold (0.40 log units) below what was measured; the range from low to high includes it.
By their numbers in this assay, from the lowest: compounds 3 and 1 (each within the scatter of the next); then compound 4. At a limit, above all of these: compound 2.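

In this assay compound 2 gives > 50000 nM, which is a limit of the assay and not a number: the limit of > 50000 nM in this assay, at which 1 of the 4 values shown sits. From the compounds shown here alone, with (4-chloro-3-(trifluoromethyl)phenyl)amino in place of 3-(trifluoromethyl)phenyl on the carbonyl carbon, the result is an at least 9.9-fold lower number from compound 2 to compound 4 (0.99 log units; beyond the scatter), the first step measured at this position, and its full size stays unknown since one end of it is a limit. The entering group brings both an amino nitrogen, with its hydrogen-bond donor, and a chlorine on the ring, so this step measures the two together and assigns the gain to neither.

The compounds shown leave open how much of the step belongs to the nitrogen and how much to the chlorine, a question that 3-(trifluoromethyl)phenylamino or 4-chloro-3-(trifluoromethyl)phenyl on the same carbonyl carbon would separate. Also open, going by these compounds, is whether the amino hydrogen itself matters, as a methylamino link or an oxygen in place of the amino nitrogen would show in this assay.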